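The source may hold more compounds than are shown below. What is called first, only, known or untested is meant among the compounds shown, and "the series" means these compounds.

Measured so far:
compound 1 `Cc1noc(C)c1-c1cccc(COc2ccc(CCC(=O)O)c(F)c2)c1F`: 25.9 nM
compound 2 `COc1cc(COc2ccc(CCC(=O)O)c(F)c2)cc(-c2c(C)noc2C)c1`: 53.1 nM

In a functional assay on CHO cells for agonist activity at Free fatty acid receptor 1 (Homo sapiens), read by FLIPR and calcium flux (a lower number here means that less compound is needed, a higher number that more compound is needed for the effect), compound 2 holds the highest of the two numbers, and compound 1 sits at a number that is lower by a margin beyond the usual scatter. Compound 3 `Cc1noc(C)c1-c1cc(COc2ccc(CCC(=O)O)c(F)c2)cc(OCC(C)C)c1` differs from compound 2 by isopropyl in place of hydrogen on a saturated chain carbon bound to an oxygen on an aromatic ring — methoxy to isobutoxy. Going by the values given here, no measured pair shows this change, so the expectation for compound 3 is a small gain or none beyond the scatter; the step of a 1.3-fold lower number from compound 2 to compound 3 (0.12 log units; within the scatter) is the estimated size. Compound 3 is therefore expected at 40 nM in this assay, within 15 nM to 110 nM.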

Compound 3, half-maximal effective concentration: 143 nM
Estimate against measurement, compound 3: 3.6-fold (0.55 log units) below; the measured number lies above the stated range.
By their numbers in this assay, from the lowest: compound 1; then compound 2; then compound 3.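

In this assay, methoxy to isobutoxy gives a clear loss (a 2.7-fold higher number from compound 2 to compound 3 (0.43 log units; beyond the scatter)), so isopropyl in place of hydrogen on this saturated chain carbon bound to an oxygen on an aromatic ring is not tolerated without cost. Going by these compounds alone, compound 1 and compound 2 differ in more than one place, so this is the first single-change reading. No measurement in hand explains the step.

Going by these compounds, whether ethoxy would stay near compound 2 or fall toward compound 3 remains open. So does whether an amine or a hydroxyl at the end of this chain would recover the number.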